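Chloro in place of methyl on compound 2

A few compounds are considered here, and "the series" means these few. Any claim that something is new, unique, unknown or untested is made for them only; others in the source may bear on it.

In a functional assay on MDA-MB-231 cells (Homo sapiens) for inhibition, read by MTT assay, with a stated time of 48 h (on this read-out higher numbers stand for weaker inhibition and lower numbers for stronger inhibition), compound 1 (`C[Se]c1ccc(N(C)c2nc(C3CC3)nc3ccccc23)cc1`) gives 18 nM and compound 2 (`Cc1nc(N(C)c2ccc([Se]C#N)c(C)c2)c2ccccc2n1`) gives 16 nM with a gap that lies within the usual scatter, so the two stand together at the low end of the three measured numbers. Compound 3 (`Cc1nc(N(C)c2ccc(OCC[Se]C#N)cc2)c2ccccc2n1`) gives 317 nM and sits beyond the scatter on the higher side of compound 2, which marks weaker inhibition.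

The change that leads from compound 2 to compound 4 (`Cc1nc(N(C)c2ccc([Se]C#N)c(Cl)c2)c2ccccc2n1`) is chloro in place of methyl on an aromatic carbon and the rest of the structure stays the same. Going by the values given here, no measured pair in this set differs in one place only, so the data hold no direct measure of this swap. The expectation therefore starts from compound 2 at 16 nM and foresees no step beyond the scatter in this assay in either direction. Compound 3 at 317 nM shows that numbers in this set can lie much further apart, but it differs from compound 2 in more than one place and says nothing direct about this swap. The estimated change is a 1.3-fold higher number from compound 2 to compound 4 (0.10 log units; within the scatter) and stays within the scatter. For compound 4 the expected value is 20 nM with an estimated range from 8 nM to 50 nM in this measurement.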

Compound 4, half-maximal inhibitory concentration: 9 nM
Compound 4: middle estimate off by 2.2-fold (0.35 log units), on the high side; measured number inside the range.
By their numbers in this assay, from the lowest: compounds 4, 2 and 1 (each within the scatter of the next); then compound 3.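

The swap gets its first direct measure in this set at an aromatic carbon ortho to a group of 3 heavy atoms and meta to a large group: in this assay, chloro in place of methyl gives a 1.8-fold lower number from compound 2 to compound 4 (0.25 log units; within the scatter). This position therefore accepts either methyl or chloro without a step beyond the scatter, with one carbon leaving, one chlorine entering, and no ring, hydrogen-bond donor, hydrogen-bond acceptor or net charge involved on either side. Nothing in the data bears on what lies behind this result.

As far as these compounds go, whether the same position tolerates a group of another kind, such as an amine, a carboxylic acid or a longer chain, remains open. Going by these compounds alone, with only this one step at hand, it is also open whether chloro in place of methyl would read the same way on the core of compound 1 or compound 3.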